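The compounds below may be only part of what the source reports. "The series", "measured", "known", "first", "only" and "open" are said of these compounds alone.

Measured compounds in an assay on microsomes from intestine for inhibition of acyl-CoA:cholesterol acyltransferase (Oryctolagus cuniculus); on this read-out lower numbers stand for stronger inhibition and higher numbers for weaker inhibition:

compound 1 `CC(C)c1cccc(C(C)C)c1NC(=O)CC(=O)OC(c1ccccc1)c1ccccc1`: 38 nM
compound 2 `CC(C)c1cccc(C(C)C)c1NC(=O)CC(=O)Oc1c(-c2ccccc2)cccc1-c1ccccc1`: 67 nM
compound 3 `CCOC(=O)CC(=O)Nc1c(C(C)C)cccc1C(C)C`: 1800 nM

Compound 1 carries the lowest of the three numbers in this assay. Compound 2 sits within the scatter of compound 1, so the two cannot be ordered. Compound 3 lies well beyond the scatter on the weaker side, the ethyl ester standing far from the two aryl-bearing esters. Among the measured compounds shown here, only these three values are in hand; no single-change step between measured compounds is available.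

Compound 4 `CC(C)c1cccc(C(C)C)c1NC(=O)CC(=O)OC(c1ccccc1)c1ccccn1` differs from compound 1 in one place: pyridin-2-yl in place of phenyl on a saturated chain carbon bound to an aromatic carbon and an oxygen next to a carbonyl group. For the measured compounds named here, the shared core of compound 1 and the ester linkage are kept; only one of the two rings on that saturated chain carbon is changed for a ring with one hetero atom. Going by the values given here, nothing among the measured compounds speaks to this exchange, so the step is expected to be small, from compound 1 to compound 4 likely no further than the usual scatter, with no direction to be read from the data. Compound 4 is therefore estimated at 55 nM in this assay, within a range of 18 nM to 170 nM, which corresponds to an expected step of a 1.4-fold higher number from compound 1 to compound 4 (0.16 log units; within the scatter).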

Compound 4, half-maximal inhibitory concentration: > 5000 nM
Compound 4: only a limit was reported; the forecaster's own chance of this, stated with the estimate: 3%; middle value at least 90-fold (1.95 log units) away from the limit.
By their numbers in this assay, from the lowest: compounds 1 and 2 (each within the scatter of the next); then compound 3. At a limit, above all of these: compound 4.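

At the saturated chain carbon bound to an aromatic carbon and an oxygen next to a carbonyl group, the two rings are not interchangeable: in this assay, pyridin-2-yl in place of phenyl gives an at least 130-fold higher number from compound 1 to compound 4 (2.11 log units; beyond the scatter). Going by these compounds, compound 4 reads > 5000 nM, which is a limit of the assay and not a number, so the full size of the step stays unknown, with a single reading setting its lower bound: the limit of > 5000 nM in this assay, at which 1 of the 4 values shown sits. Among the compounds shown here, the exchange keeps the heavy-atom count and adds one hydrogen-bond acceptor, so this position is far less forgiving of a one-atom ring change than the earlier compounds could reveal.

Open, on these data alone, is whether pyridin-3-yl or pyridin-4-yl at this place would follow phenyl or pyridin-2-yl. Equally open, as far as these compounds go, is how a cyclohexyl ring in place of phenyl would read.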